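Swapping 1H-indol-3-yl for 1H-indazol-3-yl in compound 1

A few compounds are considered here, and "the series" means these few. Any claim that something is new, unique, unknown or untested is made for them only; others in the source may bear on it.

- compound 1 `CC(=O)N1CCN(c2ccc(Nc3nccc(-c4c[nH]c5ccccc45)n3)cc2)CC1` gives 33 nM
- compound 2 `CC(=O)N1CCCN(c2cccc(Nc3nccc(-c4c[nH]c5ncccc45)n3)c2)CC1` gives 20 nM
- compound 3 `CC(=O)N1CCN(c2ccc(Nc3nccc(-c4cn(S(=O)(=O)c5ccc(C)cc5)c5ccccc45)n3)cc2)CC1` gives 1560 nM

All three numbers come from a functional assay on MV4-11 cells (Homo sapiens) for antiproliferative activity, read by resazurin assay, with a stated time of 72 h; on this read-out higher numbers stand for weaker inhibition of growth and lower numbers for stronger inhibition of growth. Compound 1 and compound 2 lie within the scatter of each other, and compound 1 stands far from compound 3. The next compound to be tested, compound 4 `CC(=O)N1CCN(c2ccc(Nc3nccc(-c4n[nH]c5ccccc45)n3)cc2)CC1`, differs from compound 1 in one place: 1H-indazol-3-yl in place of 1H-indol-3-yl on an aromatic carbon. In short, 1H-indazol-3-yl comes in place of 1H-indol-3-yl on an aromatic carbon of the shared core.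

Among the measured compounds shown here, only one measured step starts from compound 1: a 47-fold higher number from compound 1 to compound 3 (1.67 log units; beyond the scatter). That step is large, but it puts (4-methylphenyl)sulfonyl in place of hydrogen on an aromatic nitrogen, and no such group enters in compound 4. Compound 2 differs from compound 1 in more than one place, so it does not isolate any single change. No measurement compares these two groups directly, which leaves the direction open. Only a small step is therefore expected, leaning weakly towards a higher number. The estimated change is a 1.4-fold higher number from compound 1 to compound 4 (0.13 log units; within the scatter). In this assay, compound 4 is expected at 45 nM, with an estimated range from 12 nM to 170 nM.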

Compound 4, concentration for 50% growth inhibition: 346 nM
Compound 4: middle estimate off by 7.7-fold (0.89 log units), on the low side; the measured number lies above the stated range.
By their numbers in this assay, from the lowest: compounds 2 and 1 (each within the scatter of the next); then compound 4; then compound 3.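

In this assay, the step to the 1H-indazol-3-yl group is large: a 10-fold higher number from compound 1 to compound 4 (1.02 log units; beyond the scatter). Among the compounds shown here, until now, the only step beyond the scatter had put (4-methylphenyl)sulfonyl on an aromatic nitrogen, whereas this one keeps the same count of heavy atoms and hydrogen-bond donors, exchanging one carbon for a nitrogen and adding one hydrogen-bond acceptor, so the read-out at this position on an aromatic carbon responds to the make-up of the five-membered ring as well as to a large added group. No measurement here accounts for the loss in growth inhibition, and the reason for it remains unknown.

The compounds shown leave open whether the effect follows the added ring nitrogen itself or would also appear on a core other than that of compound 1, as this swap is read only once. They also leave open how a methyl group in place of the hydrogen on the aromatic nitrogen of 1H-indazol-3-yl, or a fluorine or an amine on its six-membered ring, would shift the number in this assay.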